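The compounds below may be only part of what the source reports. "The series", "measured", "known", "first", "only" and "open" are said of these compounds alone.

Compound 1, `Cc1ccc2[nH]c(=O)c(-c3nc4cc([N+](=O)[O-])ccc4[nH]3)cc2c1`: > 100000 nM
Compound 2, `O=c1[nH]c2ccccc2cc1-c1nc2cc([N+](=O)[O-])ccc2[nH]1`: > 100000 nM

Compound 1 stands only at a limit in an ADME assay on L02 cells (Homo sapiens) for cytotoxicity, read by MTT assay, with a stated time of 48 h; a lower number here means a stronger inhibitor, a higher number a weaker inhibitor. In this assay compound 1 gives > 100000 nM, which is a limit of the assay and not a measured number. Compound 2 in this assay gives > 100000 nM, again a limit rather than a number. Between these two compounds the single change is a step that the two limits leave unreadable from compound 1 to compound 2, so the two limits leave the size of that step unreadable. All that the measured pair shows is the limit of > 100000 nM in this assay, at which 2 of the 2 values shown sit.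

Compound 3, `Cc1ccc2[nH]c(=O)c(-c3nc4ccccc4[nH]3)cc2c1`, differs from compound 1 in one place: hydrogen in place of nitro on an aromatic carbon. Among the measured compounds shown here, no measured step bears directly on this change; the only step measured, from compound 1 to compound 2, concerns a different group and cannot be read. With both measured values sitting at the limit, the writer expects compound 3 to sit at the limit as well, with a step of a number no higher from compound 1 to compound 3 (the limit leaves the size open) that is expected to mean no change beyond the scatter. Compound 3 is therefore estimated at 100000 nM in this assay, with a range from 50000 nM to 300000 nM.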

Compound 3, half-maximal inhibitory concentration: > 100000 nM
Compound 3: only a limit was reported; the forecaster's own chance of this, stated with the estimate: 85%; the middle value lies on the limit itself.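

In this assay compound 3 gives > 100000 nM, a limit of the assay and not a number. Among the compounds shown here, no step can therefore be read between compound 1 and compound 3. The compounds shown leave open where any of them would give a measured value, and whether removing the nitro or methyl group changes it: the limit of > 100000 nM in this assay, at which 3 of the 3 values shown sit.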